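A few compounds are considered here, and "the series" means these few. Any claim that something is new, unique, unknown or untested is made for them only; others in the source may bear on it.

In a functional assay on HL-60 cells (Homo sapiens) for antiproliferative activity, read by MTT assay, with a stated time of 48 h (on this read-out higher numbers stand for weaker inhibition and lower numbers for stronger inhibition), compound 1 `N#Cc1nc2c(-c3nc4ccccc4[nH]3)c(N)n(CCO)c2nc1C#N` gives > 50000 nM, which is a limit of the assay and not a number. Among the measured compounds shown here, compound 2 `CN1CCN(CCCn2c(N)c(-c3nc4ccccc4[nH]3)c3nc(C#N)c(C#N)nc32)CC1` gives 750 nM, the only true number so far. For the measured compounds named here, the one measured step is an at least 66-fold lower number from compound 1 to compound 2 (1.82 log units; beyond the scatter), made by placing (4-methylpiperazin-1-yl)methyl in place of hydroxy on the chain. Compound 3 `N#Cc1nc2c(-c3nc4ccccc4[nH]3)c(N)n(CCCN3CCCCC3)c2nc1C#N` changes this new group: it has piperidin-1-yl in place of 4-methylpiperazin-1-yl on a saturated chain carbon, three bonds along the chain from an aromatic nitrogen. Going by the values given here, no measured step covers this exchange, and the large step above replaced hydroxy, which is a much bigger change. Both groups carry a six-membered non-aromatic ring, so compound 2, at 750 nM, is the best guide. The expected change, a 1.1-fold higher number from compound 2 to compound 3 (0.03 log units; within the scatter), is an estimate and stays within the scatter. For compound 3 the estimated value is 800 nM, with an expected range from 250 nM to 3000 nM.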

Compound 3, half-maximal inhibitory concentration: 1680 nM
Compound 3: the middle estimate sits 2.1-fold (0.32 log units) below what was measured; the range from low to high includes it.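

Swapping the ring at the end of the chain is not a neutral exchange: piperidin-1-yl in place of 4-methylpiperazin-1-yl gives a 2.2-fold higher number from compound 2 to compound 3 (0.35 log units; beyond the scatter). Even so, in this assay the piperidine-bearing chain in place of hydroxy gives an at least 29-fold lower number from compound 1 to compound 3 (1.47 log units; beyond the scatter), so the large gain seen earlier does not depend on 4-methylpiperazin-1-yl alone. Compound 1 stands at a limit of the assay and not at a number, so the true size of both steps from it remains unknown: the limit of > 50000 nM in this assay, at which 1 of the 3 values shown sits.

The compounds shown do not separate the effect of the ring from that of chain length, as compound 1 differs from the others in both. Going by these compounds, a morpholin-4-yl or a dimethylamino group at the end of the 3-carbon propyl chain, or a piperidin-1-yl on a shorter ethyl chain, remains open.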